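This account rests on a few compounds, and the source may have more. Where it says the series, first, only, none or still open, it means among the compounds named here.

Compound 1, with the structure `O=C(Nc1ccccc1)c1cccc(Br)c1`, sets the starting point. In an assay for inhibition of HSP60/HSP10 (Homo sapiens), with a stated time of 60 min (a lower number here means a stronger inhibitor, a higher number a weaker inhibitor), compound 1 gives > 100000 nM, which is a limit of the assay and not a number. Two neighbours of compound 1 have been measured in the same way. Compound 2, `O=C(Nc1ccccc1)c1cc(Br)cc(Br)c1`, gives > 100000 nM in this assay, again a limit. Compound 3, `COc1ccc(Br)cc1C(=O)Nc1ccccc1`, gives > 100000 nM in this assay, once more a limit. The step from compound 1 to compound 2, bromo in place of hydrogen on an aromatic carbon, reads as a step that the two limits leave unreadable from compound 1 to compound 2, and the step from compound 1 to compound 3, methoxy in place of hydrogen on an aromatic carbon, reads as a step that the two limits leave unreadable from compound 1 to compound 3; neither can be sized because of the limit of > 100000 nM in this assay, at which 3 of the 3 values shown sit. The compound now in question, compound 4, has the structure `O=C(Nc1ccccc1)c1cccc(Br)c1O` and differs from compound 1 by hydroxy in place of hydrogen on an aromatic carbon. Among the compounds with values here, both measured steps from compound 1 are unreadable, so no measured step gives a direction or a size for this change. With every measured value sitting at the limit, compound 4 is expected to land near that limit as well, at an estimated 150000 nM with a range from 30000 nM to 600000 nM. The expected step from compound 1 to compound 4 is therefore a step that the limit leaves unreadable from compound 1 to compound 4, with no direction that the data can support.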

Compound 4, half-maximal inhibitory concentration: > 100000 nM
Compound 4: no number, only a limit; the forecaster's own chance of this, stated with the estimate: 80%; the middle value lies beyond the limit too.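

In this assay compound 4 gives > 100000 nM, which is a limit and not a number. No new step can be read between compound 1 and compound 4 because both sit at the same limit: the limit of > 100000 nM in this assay, at which 4 of the 4 values shown sit. The compounds shown leave open whether any change to the core of compound 1 would give a measurable value in this assay.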